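This account rests on a few compounds, and the source may have more. Where it says the series, first, only, none or still open, it means among the compounds named here.

Within the data shown here, compound 2, with structure `COc1ccc2c(OCC[C@@H]3NC(=O)N(C)CCCC/C=C\[C@@H]4C[C@@]4(C(=O)NS(=O)(=O)C4CC4)NC3=O)cc(-c3nc(C(C)C)cs3)nc2c1Cl`, is the only compound of this pair for which an ADME assay on cells (Homo sapiens) for activation (on this read-out higher numbers stand for lower toxicity in this test and lower numbers for higher toxicity in this test), gives a number: compound 2 gives 40400 nM. Compound 1, with structure `COc1ccc2c(OCC[C@@H]3NC(=O)N(C)CCCC/C=C\[C@@H]4C[C@@]4(C(=O)NS(=O)(=O)C4(C#N)CC4)NC3=O)cc(-c3nc(C(C)C)cs3)nc2c1Cl`, gives in this assay only a limit, > 75000 nM, and the limit of > 75000 nM in this assay, at which 1 of the 2 values shown sits, records that this limit is all that is known for it. Among the measured compounds shown here, the one measured step, an at least 1.8-fold lower number from compound 1 to compound 2 (0.26 log units; that floor lies within the scatter), therefore has only a floor and cannot be fixed as a real change.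

Compound 3, with structure `COc1ccc2c(OCC[C@@H]3NC(=O)N(C)CCCC/C=C\[C@@H]4C[C@@]4(C(=O)NS(=O)(=O)N4CCC[C@H]4C#N)NC3=O)cc(-c3nc(C(C)C)cs3)nc2c1Cl`, differs from compound 2 by 2-cyanopyrrolidin-1-yl in place of cyclopropyl on a sulfonyl sulfur. The measured step concerns the nitrile on the cyclopropyl and bears on this change only loosely, since compound 3 again carries a nitrile, now on the entering ring. On this basis no step beyond the scatter is expected; the estimated step is a 1.2-fold higher number from compound 2 to compound 3 (0.09 log units; within the scatter). Compound 3 is estimated to give 50000 nM in this assay, within a range from 22000 nM to 110000 nM.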

Compound 3, half-maximal cytotoxic concentration: 28300 nM
Estimate against measurement, compound 3: 1.8-fold (0.25 log units) above; the measured number falls inside the stated range.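

On the sulfonyl sulfur, 2-cyanopyrrolidin-1-yl in place of cyclopropyl gives in this assay a 1.4-fold lower number from compound 2 to compound 3 (0.15 log units; within the scatter), so this position accepts the nitrile-bearing five-membered ring without a step that can be told from the scatter. Set against 1-cyanocyclopropyl at the same place, the same ring gives an at least 2.6-fold lower number from compound 1 to compound 3 (0.42 log units; beyond the scatter), the first step here that clears the scatter. Compound 1 is known only through a limit, so that step remains a floor and its true size is not fixed: the limit of > 75000 nM in this assay, at which 1 of the 3 values shown sits.

The compounds shown leave open how a plain pyrrolidin-1-yl without the nitrile, or an open-chain dimethylamino group, would read on the sulfonyl sulfur, and so whether the ring or the nitrile goes with the lower number. Also open, as far as these compounds go, is how the other configuration of the defined stereocentre in 2-cyanopyrrolidin-1-yl would read.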